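Swapping a methoxy for a methyl on the amide ring

The source may report more compounds than this note shows. Statements on the series, on what has been measured and on what is new or still open speak of the compounds shown alone.

Of the compounds shown here, two sharing one core have been measured in a functional assay on MCF7 cells (Homo sapiens) for antiproliferative activity, read by CCK-8 assay, with a stated time of 72 h (a higher number here means a weaker inhibitor, a lower number a stronger inhibitor), so far. Compound 1 `COc1ccc(C(=O)Nc2cccc(-c3oc4cc(-c5ccc(F)cc5)ccc4c(=O)c3O)c2)cc1` gives 6250 nM, and compound 2 `COc1ccccc1C(=O)Nc1cccc(-c2oc3cc(-c4ccc(F)cc4)ccc3c(=O)c2O)c1` gives 2100 nM. Among the measured compounds shown here, the single measured step, a 3.0-fold lower number from compound 1 to compound 2 (0.47 log units; beyond the scatter), leaves compound 2 with the lowest number of the two, its only neighbour being compound 1 with a higher one.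

Compound 3 `Cc1ccccc1C(=O)Nc1cccc(-c2oc3cc(-c4ccc(F)cc4)ccc3c(=O)c2O)c1` is not yet measured. It differs from compound 2 in one place: methyl in place of methoxy on an aromatic carbon. For the measured compounds named here, no measured step touches a change of this kind; the one known step moved a methoxy from one position to another rather than replacing it, so it offers only weak guidance. The expected outcome is therefore a change in this assay that stays within the usual scatter, described by a 1.2-fold higher number from compound 2 to compound 3 (0.08 log units; within the scatter). Compound 3 is accordingly estimated at 2500 nM, with a range from 1000 nM to 6500 nM.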

Compound 3, half-maximal inhibitory concentration: 2280 nM
Compound 3: middle estimate off by 1.1-fold (0.04 log units), on the high side; the range from low to high includes it.
By their numbers in this assay, from the lowest: compounds 2 and 3 (each within the scatter of the next); then compound 1.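

In this assay, the change of 2-methoxyphenyl to 2-methylphenyl gives a 1.1-fold higher number from compound 2 to compound 3 (0.04 log units; within the scatter) and stays within the scatter, so at this place, ortho to a large group, the methoxy oxygen and its hydrogen-bond acceptor can go with no measurable effect on the number. The other new step, a 2.7-fold lower number from compound 1 to compound 3 (0.44 log units; beyond the scatter), shows that a 2-methylphenyl group, like the 2-methoxyphenyl group of compound 2, reads lower than the 4-methoxyphenyl group of compound 1, and neither of these compounds goes against that. Nothing here explains why methoxy and methyl read alike at this place.

Whether any group is needed there remains open, since a plain phenyl ring is not among these compounds. A chlorine, an ethyl chain or an amine in the same place could also read differently.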